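This account rests on a few compounds, and the source may have more. Where it says the series, first, only, none or still open, it means among the compounds named here.

Compound 1, `O=C(O)c1cccc(C2=C(c3cc(Br)ccc3OCc3ccccc3)CCC2)c1`, was tested in an assay on isolated protein for inhibition of prostaglandin E2 receptor EP3 subtype (Homo sapiens); a lower number here means a stronger inhibitor, a higher number a weaker inhibitor. In this assay compound 1 reaches only the limit of < 3170 nM, a boundary of the measurement rather than a number. Compound 2, `O=C(O)c1cccc(C2=C(c3cc(Br)ccc3OCc3ccc(F)cc3F)CCC2)c1`, differs from it by carrying 2,4-difluorophenyl in place of phenyl on a saturated chain carbon bound to an oxygen on an aromatic ring. In this assay compound 2 likewise gives only the limit of < 3170 nM. The step that the two limits leave unreadable from compound 1 to compound 2 therefore has no readable size, because of the limit of < 3170 nM in this assay, at which 2 of the 2 values shown sit.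

Compound 3, `O=C(O)c1cccc(C2=C(c3cc(Cl)ccc3OCc3ccccc3)CCC2)c1`, has not yet been measured. It differs from compound 1 by chloro in place of bromo on an aromatic carbon. Within the data shown here, no measured step replaces bromo by anything else, and the single known step, from compound 1 to compound 2, shows two limits and so offers no size to borrow. With nothing pointing either way, the change is expected to leave compound 3 on the same side of the limit as compound 1. For compound 3 the expected step is a step that the limit leaves unreadable from compound 1 to compound 3, no further than the scatter. For compound 3 the estimated value in this assay is 900 nM, within a range from 150 nM to 4000 nM.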

Compound 3, half-maximal inhibitory concentration: < 3170 nM
Compound 3 gave a limit, no number; the forecaster's own chance of this, stated with the estimate: 65%; the middle value lies beyond the limit too.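

No size can be read for chloro in place of bromo between compound 1 and compound 3, because both results in this assay are limits rather than numbers: the limit of < 3170 nM in this assay, at which 3 of the 3 values shown sit. The compounds shown leave open how compound 1, compound 2 and compound 3 truly rank, and whether either change alters inhibition at all.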